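Pyridine for Methoxyphenyl at the Benzylic Amine Position

This account rests on a few compounds, and the source may have more. Where it says the series, first, only, none or still open, it means among the compounds named here.

Compound 3 `COc1ccc(CNc2ccc(-c3c(N)nc(N)nc3COCc3ccccc3)cc2)cc1` gives 90 nM in a functional assay on CHOK cells for antagonist activity at growth hormone secretagogue receptor type 1 (Homo sapiens), read by calcium flux (on this read-out lower numbers stand for stronger inhibition and higher numbers for weaker inhibition), the highest number among the three measured compounds. Compound 1 `CC(=O)c1ccc(CNc2ccc(-c3c(N)nc(N)nc3COCc3ccccc3)cc2)cc1` gives 10 nM and compound 2 `N#Cc1ccc(CNc2ccc(-c3c(N)nc(N)nc3COCc3ccccc3)cc2)cc1` gives 19 nM; the step of a 9.0-fold higher number from compound 1 to compound 3 (0.95 log units; beyond the scatter) and the step of a 4.7-fold higher number from compound 2 to compound 3 (0.68 log units; beyond the scatter) both show that the group on this ring matters. Compound 4 `Nc1nc(N)c(-c2ccc(NCc3ccncc3)cc2)c(COCc2ccccc2)n1` carries pyridin-4-yl in place of 4-methoxyphenyl on a saturated chain carbon bound to a nitrogen on an aromatic ring. Going by the values given here, no measured step swaps the ring itself, so the closest guide is that the methoxy-bearing ring is the weakest of the three variants; removing it and placing a ring nitrogen is expected to give at most a modest shift, a 1.8-fold lower number from compound 3 to compound 4 (0.26 log units; within the scatter). Compound 4 is therefore estimated at 50 nM, between 12 nM and 220 nM.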

Compound 4, half-maximal inhibitory concentration: 86 nM
Estimate against measurement, compound 4: 1.7-fold (0.24 log units) below; low and high end bracket the measured number.
By their numbers in this assay, from the lowest: compounds 1 and 2 (each within the scatter of the next); then compounds 4 and 3 (each within the scatter of the next).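

Pyridin-4-yl in place of 4-methoxyphenyl gives a 1.0-fold lower number from compound 3 to compound 4 (0.02 log units; within the scatter), so this assay does not separate these two rings at this position. The same pyridin-4-yl group gives an 8.6-fold higher number from compound 1 to compound 4 (0.93 log units; beyond the scatter) and a 4.5-fold higher number from compound 2 to compound 4 (0.66 log units; beyond the scatter), which leaves the 4-acetylphenyl and 4-cyanophenyl compounds with the lowest numbers of the four. No supporting data are available to explain these differences.

The compounds shown leave open how a pyridin-3-yl ring, or a phenyl ring carrying an amine or a carboxylic acid, would behave at this position.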